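Halogenated benzyl thioethers on a shared phenolic core

The compounds below may be only part of what the source reports. "The series", "measured", "known", "first", "only" and "open" are said of these compounds alone.

Three compounds share one core and differ only in the halogenated phenyl group carried on a saturated chain carbon bound to a sulfur. Compound 1, `COc1cc(-c2nnc(SCc3ccc(Cl)cc3)o2)ccc1O`, carries a 4-chlorophenyl there, and in an ADME assay on cells (Mus musculus, strain BALB/c) for cytotoxicity, read by MTT assay, with a stated time of 24 h (a higher number here means that more compound is tolerated, a lower number that less compound is tolerated), compound 1 gives 480000 nM. Compound 2, `COc1cc(-c2nnc(SCc3ccc(F)cc3F)o2)ccc1O`, carries a 2,4-difluorophenyl, and in this assay compound 2 gives 520000 nM. Compound 3, `COc1cc(-c2nnc(SCc3ccccc3Br)o2)ccc1O`, carries a 2-bromophenyl, and in this assay compound 3 gives 363000 nM. Compound 3 stands together with the other two: the step of a 1.3-fold lower number from compound 1 to compound 3 (0.12 log units; within the scatter) and the step of a 1.4-fold lower number from compound 2 to compound 3 (0.16 log units; within the scatter) both lie within the scatter, as does the step of a 1.1-fold higher number from compound 1 to compound 2 (0.03 log units; within the scatter) between the other pair.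

Compound 4, `COc1cc(-c2nnc(SCc3ccc(F)cc3)o2)ccc1O`, is the next member. Its change from compound 3 is 4-fluorophenyl in place of 2-bromophenyl on a saturated chain carbon bound to a sulfur. Every halogen exchange on this phenyl group seen so far, whether of halogen identity or of its position on the ring, has left the number within the scatter, so no step beyond the scatter is expected in this assay here either; compound 4 is expected to give a step of a 1.2-fold higher number from compound 3 to compound 4 (0.09 log units; within the scatter). The estimate for compound 4 in this assay is 450000 nM, with a range from 300000 nM to 700000 nM.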

Compound 4, half-maximal cytotoxic concentration: 685000 nM
Compound 4: middle estimate off by 1.5-fold (0.18 log units), on the low side; the range from low to high includes it.
By their numbers in this assay, from the lowest: compounds 3, 1, 2 and 4 (each within the scatter of the next).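

In this assay, the step from the 2-bromophenyl to the 4-fluorophenyl (a 1.9-fold higher number from compound 3 to compound 4 (0.28 log units; within the scatter)) is the largest yet seen at this saturated chain carbon bound to a sulfur, and it still lies within the scatter, so a change in both the halogen and its place on the ring leaves no readable difference. Within the data shown here, compound 4 also adds the first exchanges of a single atom on the phenyl group: hydrogen in place of fluoro on an aromatic carbon (a 1.3-fold higher number from compound 2 to compound 4 (0.12 log units; within the scatter)) and fluoro in place of chloro on an aromatic carbon (a 1.4-fold higher number from compound 1 to compound 4 (0.15 log units; within the scatter)), both within the scatter, so all four compounds stand together with no exception among them. Nothing available gives a reason for this flat picture.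

The compounds shown carry only halogens on this phenyl group, so they leave open whether an amine or a carboxylic acid there, or a longer chain in place of the single saturated carbon bound to the sulfur, would give a step beyond the scatter. They also leave open how a phenyl group with no halogen at all would stand.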